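Meta-halogen swap on the triazole aryl: from fluorine to chlorine

This account rests on a few compounds, and the source may have more. Where it says the series, first, only, none or still open, it means among the compounds named here.

Compound 1 `Cc1ccc(-n2cc(-c3ccccc3NS(=O)(=O)c3c[nH]c(=O)[nH]c3=O)nn2)cc1`: 6390 nM
Compound 2 `O=c1[nH]cc(S(=O)(=O)Nc2ccccc2-c2cn(-c3cccc(F)c3)nn2)c(=O)[nH]1`: > 20000 nM

For the measured compounds named here, in a functional assay on SGC-7901 cells (Homo sapiens) for antiproliferative activity, read by MTT assay, with a stated time of 24 h (on this read-out lower numbers stand for stronger inhibition and higher numbers for weaker inhibition), compound 1 gives 6390 nM, the only plain number among the two measured compounds. Compound 2 reaches only a limit of the assay, > 20000 nM. The new compound 3 `O=c1[nH]cc(S(=O)(=O)Nc2ccccc2-c2cn(-c3cccc(Cl)c3)nn2)c(=O)[nH]1` differs from compound 1 by 3-chlorophenyl in place of 4-methylphenyl on an aromatic nitrogen. Going by the values given here, the one measured step that bears on this, an at least 3.1-fold higher number from compound 1 to compound 2 (0.49 log units; beyond the scatter), also replaced the 4-methylphenyl with a halogen-bearing phenyl and ran into (the limit of > 20000 nM in this assay, at which 1 of the 2 values shown sits). A step of similar size and direction is therefore expected, a 2.8-fold higher number from compound 1 to compound 3 (0.45 log units; beyond the scatter), and compound 3 is estimated at 18000 nM, between 6000 nM and 45000 nM.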

Compound 3, half-maximal inhibitory concentration: 2270 nM
Compound 3: the middle estimate sits 7.9-fold (0.90 log units) above what was measured; the whole stated range lies above it.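

In this assay, a halogen-bearing phenyl on the aromatic nitrogen does not have to weaken inhibition: 3-chlorophenyl in place of 4-methylphenyl gives a 2.8-fold lower number from compound 1 to compound 3 (0.45 log units; beyond the scatter). The choice of halogen also matters here, since chloro in place of fluoro gives an at least 8.8-fold lower number from compound 2 to compound 3 (0.94 log units; beyond the scatter). Compound 2 stands at a limit of the assay, not at a number: the limit of > 20000 nM in this assay, at which 1 of the 3 values shown sits.

As far as these compounds go, whether bromo or an amine on the same phenyl would match chloro remains open. So does the reading of a 4-chlorophenyl, which would show whether the ring position of the chlorine counts.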